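The compounds below may be only part of what the source reports. "The series", "measured", "known", "first", "only" and "open" are said of these compounds alone.

Working notes on the series around compound 3 `O=C1CCCCC1S(=O)(=O)Nc1cc(C(F)(F)F)cc(C(F)(F)F)c1` and its two measured relatives, compound 1 `O=C1CCCCC1S(=O)(=O)Nc1ccc(Cl)cc1` and compound 2 `O=C1CCCCC1S(=O)(=O)Nc1cc(C(F)(F)F)ccc1C(F)(F)F`.

In a functional assay on HL-60 cells (Homo sapiens) for antiproliferative activity, read by MTT assay, tested at 100 ug/mL (on this read-out higher numbers stand for more inhibition at the one concentration tested (going by the name of the read-out) and lower numbers for less inhibition), compound 1 gives -13%, compound 2 gives 95.7%, and compound 3 gives 95.9%. On these three numbers compound 3 carries the highest value; its nearest neighbour is compound 2, whose number sits lower by an amount within the usual scatter, so the two cannot be ordered against each other. The furthest is compound 1, which lies far below compound 3, well beyond the scatter. Among the compounds with values here, both compounds that bear two trifluoromethyl groups on the aryl ring sit at the top; the single chloro-bearing compound 1 sits at the bottom.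

Compound 4 `O=C1CCCCC1S(=O)(=O)Nc1cccc(C(F)(F)F)c1` is not yet measured. Relative to compound 3 the change is hydrogen in place of trifluoromethyl on an aromatic carbon. Within the data shown here, no step between measured compounds isolates this change, and no compound with a single trifluoromethyl group has been run. Compound 1 shows that one small substituent on the ring can leave the number at -13%, whereas compound 3 with two trifluoromethyl groups reaches 95.9%; compound 4 is therefore expected to fall between those, with a downward step a number 50.9 percentage points lower from compound 3 to compound 4 (beyond the scatter) beyond the scatter. The estimate for compound 4 in this assay is 45%, with a wide range from -5% to 90%.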

Compound 4, a percentage reported as inhibition, at one concentration (the size of the read-out at that concentration, not a potency): 17%
The estimate for compound 4 lay 28 percentage points above the measured number, and the stated range covers the measured number.
By their numbers in this assay, from the lowest: compound 1; then compound 4; then compounds 2 and 3 (each within the scatter of the next).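

In this assay, within the data shown here, the first single-place change can now be read: hydrogen in place of trifluoromethyl on an aromatic carbon gives a number 78.9 percentage points lower from compound 3 to compound 4 (beyond the scatter), and the same kind of exchange gives a number 78.7 percentage points lower from compound 2 to compound 4 (beyond the scatter). Among these compounds, one trifluoromethyl group on the shared core therefore does not sustain the high inhibition seen with two, and the loss is large from either compound carrying two such groups. Nothing measured here speaks to the reason for this drop.

Open, from the compounds shown here alone, is whether a nitrile or a methoxy group in place of the second trifluoromethyl group would keep the inhibition of compound 3 or fall to the level of compound 4. Going by these compounds, because each number comes from one concentration, the potencies of compound 2 and compound 3 also remain open.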